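Working notes: isopropoxy to methylamino

This account rests on a few compounds, and the source may have more. Where it says the series, first, only, none or still open, it means among the compounds named here.

Measured in a physicochemical assay for lipophilicity, in phosphate buffer, measured as octanol-water partition, at pH 11.5 (on this read-out higher numbers stand for higher lipophilicity and lower numbers for lower lipophilicity), so far
Compound 1 `CCOC(=N)NC(=N)Nc1ccc(Cl)cc1` gives 2.32 here
Compound 2 `CC(C)OC(=N)NC(=N)Nc1ccc(Cl)cc1` gives 2.64 here

Compound 2 stands highest of the two, with compound 1 nearest. The next structure is compound 3 `CNC(=N)NC(=N)Nc1ccc(Cl)cc1`, with methylamino in place of isopropoxy on a carbon with a double bond to nitrogen. Among the measured compounds shown here, only one measured step bears on this, a number 0.32 log units higher from compound 1 to compound 2 (beyond the scatter), a modest rise with methyl in place of hydrogen on the saturated chain carbon bound to oxygen. For the measured compounds named here, no measured step covers the full exchange, so a fall larger than that rise is expected in this assay. The expected size is a number 1.24 log units lower from compound 2 to compound 3 (beyond the scatter) in this estimate. For compound 3 the estimated value is 1.4 as a middle, with 0.7 to 2 as the expected range.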

Compound 3, partition coefficient: 1.58
For compound 3 the middle estimate is 0.18 log units below the measured one, within the range that was stated.
By their numbers in this assay, from the lowest: compound 3; then compound 1; then compound 2.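

In this assay, exchange on the carbon with a double bond to nitrogen gives larger changes than the earlier chain change: methylamino in place of isopropoxy gives a number 1.06 log units lower from compound 2 to compound 3 (beyond the scatter), and methylamino in place of ethoxy gives a number 0.74 log units lower from compound 1 to compound 3 (beyond the scatter). Both falls lie beyond the scatter and run opposite to the earlier rise, a number 0.32 log units higher from compound 1 to compound 2 (beyond the scatter). Nothing measured here accounts for these falls.

Both exchanges alter the linking atom and the chain together, so their contributions remain unseparated. Methoxy or dimethylamino on this carbon would help to separate them.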